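A Chloro Substitution Carried Over to a Second Core

The compounds below may be only part of what the source reports. "The series", "measured", "known", "first", "only" and "open" are said of these compounds alone.

Compound 1 `O=C1OC(c2ccc(Cl)cc2)=C/C1=C\c1ccccc1` gives 18.9% in a functional assay on the whole organism (strain Wistar) for inhibition, with Rattus norvegicus as the target, with stated times of 30 min and 2 h, at a dose of 20 mg/kg by the oral route; on this read-out lower numbers stand for less inhibition and higher numbers for more inhibition at the one dose given (going by the name of the read-out).
Compound 2 `O=C1OC(c2ccc(Cl)cc2)=C/C1=C\c1ccc(Cl)cc1` gives 40% in this assay.
Compound 3 `O=C1/C(=C/c2ccccc2)C=C(c2ccc(Cl)cc2)N1Cc1ccccc1` gives 24% in this assay.

Compound 2 differs from compound 1 in a single place: chloro in place of hydrogen on an aromatic carbon. This one change produced a number 21.1 percentage points higher from compound 1 to compound 2 (beyond the scatter). Compound 3 is built on a different core from compound 1, and the difference between the two cores is not broken down here. In this assay compound 3 and compound 1 lie within the scatter of each other, while compound 2 stands beyond the scatter above compound 3.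

Compound 4 `O=C1/C(=C/c2ccc(Cl)cc2)C=C(c2ccc(Cl)cc2)N1Cc1ccccc1` has not yet been measured. It carries the same change onto the core of compound 3: chloro in place of hydrogen on an aromatic carbon. The place is described in the same words as for the earlier pair, so this is the same change on a different core.

The expectation for compound 4 rests on compound 3 giving 24% and on the earlier step of a number 21.1 percentage points higher from compound 1 to compound 2 (beyond the scatter). Among the compounds with values here, since only one earlier example exists, a somewhat smaller step is expected, and the step expected for compound 4 is a number 16 percentage points higher from compound 3 to compound 4 (beyond the scatter). For compound 4 the estimated value in this assay is 40%, with a likely range from 25% to 58%.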

Compound 4, a percentage reported as inhibition, in the whole organism at one dose (the size of the read-out at that dose, not a potency): 58.7%
The estimate for compound 4 lay 18.7 percentage points below the measured number; the measured number lies above the stated range.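

Replacing phenyl with 4-chlorophenyl on the second core gives a number 34.7 percentage points higher from compound 3 to compound 4 (beyond the scatter) in this assay, so the number rises here as it did on the core of compound 1. The two rises point the same way and cannot be told apart in size: the same change on two cores in this assay, a number 21.1 percentage points higher (beyond the scatter) from compound 1 to compound 2 and a number 34.7 percentage points higher (beyond the scatter) from compound 3 to compound 4, 13.6 percentage points apart, within the scatter of two such steps

This shows that the gain from the chloro group carried over from one core to the other in these two pairs, but it does not show that the gain is larger on the second core, and two pairs tested at a single dose give no measure of potency or a general rule.

The compounds shown leave open whether another group on the same aromatic carbon, such as fluoro, methoxy or an amine, would raise the number as chloro does. They also leave open whether the same change would give a similar rise on a third core.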